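From methylamino to propylamino: what size of step?

A few compounds are considered here, and "the series" means these few. Any claim that something is new, unique, unknown or untested is made for them only; others in the source may bear on it.

Compound 1 `CCN(CCNC(=O)c1cc(Cl)c(N)cc1OC)Cc1ccccc1OC` gives 10 mg/kg
Compound 2 `CNc1cc(OC)c(C(=O)NC2CCN(Cc3ccccc3)C2)cc1Cl` gives 0.016 mg/kg
Compound 3 `CCN1CCC(NC(=O)c2cc(Cl)c(NC)cc2OC)C1` gives 10 mg/kg

In a functional assay on the whole organism with Rattus norvegicus as the target (on this read-out lower numbers stand for an effect already at smaller amounts and higher numbers for an effect only at larger amounts of compound), compound 2 has the lowest of the three numbers at 0.016 mg/kg and lies well clear of the other two. Compound 4 `CCCNc1cc(OC)c(C(=O)NC2CCN(Cc3ccccc3)C2)cc1Cl` differs from compound 2 in one place (ethyl in place of hydrogen on a saturated chain carbon bound to a nitrogen on an aromatic ring) and so carries propylamino where compound 2 carries methylamino.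

Going by the values given here, the only measured step (a 630-fold higher number from compound 2 to compound 3 (2.80 log units; beyond the scatter)) is large, but it puts methyl in place of phenyl at a different place in the molecule. Among the compounds with values here, no measured step touches the methylamino group, so that size cannot simply be carried over. Within the data shown here, it shows only that numbers in this small set can move far. Compound 2 at 0.016 mg/kg has no lower neighbour here, so a moderate rise in this assay is expected rather than a fall. The expected change is a 5.0-fold higher number from compound 2 to compound 4 (0.70 log units; beyond the scatter) and carries wide margins. For compound 4 the estimated value is 0.08 mg/kg with an expected range of 0.012 mg/kg to 0.5 mg/kg around it.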

Compound 4, dose for half-maximal effect: 17 mg/kg
Compound 4: the middle estimate sits 210-fold (2.33 log units) below what was measured; the measured number lies above the stated range.
By their numbers in this assay, from the lowest: compound 2; then compounds 1, 3 and 4 (each within the scatter of the next).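

In this assay, the methylamino group turns out to matter as much as any other change seen so far: putting propylamino in its place, with ethyl in place of hydrogen on the saturated chain carbon, gives a 1100-fold higher number from compound 2 to compound 4 (3.03 log units; beyond the scatter). Earlier, only the change of phenyl to methyl at the ring amine nitrogen had moved the number away from compound 2, so its low value now depends on at least two separate places in the molecule. Even this small addition, with no ring, no hydrogen-bond donors and no hydrogen-bond acceptors, is enough to lose that low value, and nothing shown here explains the size of the step.

Going by these compounds, what stays open is how the number changes along the way from methylamino to propylamino, and an ethylamino group would speak to that. A plain amino group on the same core would show whether even the methyl can be removed, and a butylamino chain would show whether the number moves further.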